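The compounds below may be only part of what the source reports. "The series", "measured", "known", "first", "only" and "open" are said of these compounds alone.

Working notes on the series. In a functional assay on PC-3 cells (Homo sapiens) for cytotoxicity, read by MTT assay, with a stated time of 72 h (on this read-out higher numbers stand for weaker inhibition and lower numbers for stronger inhibition), compound 1 `COc1ccc(C(=O)c2cc(OC)c(OC)c(OC)c2)cc1NC(=O)/C=C/c1ccc(C(F)(F)F)cc1` gives 3500 nM, compound 2 `COc1ccc(/C=C/C(=O)Nc2cc(C(=O)c3cc(OC)c(OC)c(OC)c3)cc(OC)c2OC)cc1N` gives 11100 nM, and compound 3 `C#CCOc1cccc(/C=C/C(=O)Nc2cc(C(=O)c3cc(OC)c(OC)c(OC)c3)cc(OC)c2OC)c1` gives 10100 nM. Compound 3 thus stands second highest of the three, within the scatter of compound 2 and beyond it from compound 1. Among the compounds with values here, the only single-point step measured, a 1.1-fold lower number from compound 2 to compound 3 (0.04 log units; within the scatter), swapped the aryl group on the chain and moved nothing. Compound 4 `COc1cc(C(=O)c2cc(OC)c(OC)c(OC)c2)cc(NC(=O)/C=C/c2ccc(C(F)(F)F)cc2)c1OC` takes the same route: 4-(trifluoromethyl)phenyl in place of 3-(propargyloxy)phenyl on a double-bonded chain carbon bound to a double-bonded chain carbon. Within the data shown here, the entering group is the one carried by compound 1, whose 3500 nM sits below compound 3 by more than the scatter, though on a different core, so no measured step bears directly on it. The step of a 1.7-fold lower number from compound 3 to compound 4 (0.23 log units; within the scatter) is therefore expected to be small and downward at most. Compound 4 is estimated at 6000 nM, range 2500 nM to 14000 nM.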

Compound 4, half-maximal inhibitory concentration: 4200 nM
Beside the measured number, compound 4's estimate is 1.4-fold (0.15 log units) above it, within the range that was stated.
By their numbers in this assay, from the lowest: compounds 1 and 4 (each within the scatter of the next); then compounds 3 and 2 (each within the scatter of the next).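

With 4-(trifluoromethyl)phenyl entering, the aryl place on the chain shows a 2.4-fold lower number from compound 3 to compound 4 (0.38 log units; beyond the scatter) and a 2.6-fold lower number from compound 2 to compound 4 (0.42 log units; beyond the scatter) where the earlier aryl swap stayed within the scatter. Methoxy in place of hydrogen on an aromatic carbon, with that aryl group held, gives a 1.2-fold higher number from compound 1 to compound 4 (0.08 log units; within the scatter) so this pair shows no separation for the extra methoxy. No evidence bears on the cause of these steps.

Open, going by these compounds, is whether a carboxylic acid or a dimethylamino group in place of trifluoromethyl would keep the direction of these steps. Also open, on these data alone, is whether a longer chain between the amide carbonyl and the aryl group would hold them.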